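This account rests on a few compounds, and the source may have more. Where it says the series, first, only, none or still open, it means among the compounds named here.

Compound 1 `CCCCC(OC)c1cccc(NC(=O)NCCCCl)c1` gives 50000 nM in a functional assay on MCF7 cells (Homo sapiens) for antiproliferative activity, with a stated time of 48 h; on this read-out lower numbers stand for stronger inhibition and higher numbers for weaker inhibition.
Compound 2 `CCCCCc1cccc(NC(=O)CCCCl)c1` gives > 100000 nM in this assay, which is a limit of the assay and not a number.

In this assay, among the measured compounds shown here, compound 2 therefore stands at the limit of > 100000 nM in this assay, at which 1 of the 2 values shown sits, while compound 1 is the only compound with a number. Compound 3 `CCCCC(OC)c1cccc(NC(=O)CCCCl)c1` differs from compound 2 by methoxy in place of hydrogen on a saturated chain carbon bound to an aromatic carbon and a saturated chain carbon. For the measured compounds named here, no measured pair shows this change alone, so its step size is not known; compound 1, which also carries the methoxy group, gives 50000 nM. Compound 3 is expected to come out near that figure, at 60000 nM, within 20000 nM to 200000 nM. The expected step of an at least 1.6-fold lower number from compound 2 to compound 3 (0.22 log units; that floor lies within the scatter) is thus modest, and the assay may again report only a limit.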

Compound 3, half-maximal inhibitory concentration: > 100000 nM
Compound 3: no number, only a limit; the forecaster's own chance of this, stated with the estimate: 45%; middle value at least 1.6-fold (0.22 log units) away from the limit.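

In this assay compound 3 gives a limit and not a number, so methoxy in place of hydrogen on this saturated chain carbon cannot be sized, and the step from compound 2 cannot be read. The change on the carbonyl carbon, 3-chloropropyl in place of (3-chloropropyl)amino, can be read as an at least 2.0-fold higher number from compound 1 to compound 3 (0.30 log units; that floor lies within the scatter). Limits now make up most of the values shown: the limit of > 100000 nM in this assay, at which 2 of the 3 values shown sit.

Going by these compounds, how far the methoxy group matters with (3-chloropropyl)amino on the carbonyl carbon remains open. So does whether a hydroxyl or an ethoxy group at this carbon would give a number in this assay.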